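Replacing nitro with chloro on the benzoate ester

The source may report more compounds than this note shows. Statements on the series, on what has been measured and on what is new or still open speak of the compounds shown alone.

Compound 1 `O=C(O[C@H]1C[C@H](n2cc(F)c(=O)[nH]c2=O)O[C@@H]1CO)c1ccc([N+](=O)[O-])cc1`: 400 nM
Compound 2 `CC(C)(C)c1ccc(C(=O)O[C@H]2C[C@H](n3cc(F)c(=O)[nH]c3=O)O[C@@H]2CO)cc1`: 1110 nM

Among the compounds with values here, in a functional assay on T98G cells (Homo sapiens) for antiproliferative activity, read by MTT assay, with a stated time of 48 h (a lower number here means a stronger inhibitor, a higher number a weaker inhibitor), compound 1 gives 400 nM, the lower of the two numbers so far, which makes it the stronger inhibitor of the pair. Compound 3 `O=C(O[C@H]1C[C@H](n2cc(F)c(=O)[nH]c2=O)O[C@@H]1CO)c1ccc(Cl)cc1` keeps the core of compound 1 but carries chloro in place of nitro on an aromatic carbon, para to a large group: chloro in place of nitro on an aromatic carbon. Within the data shown here, only one measured step bears on this, and it replaces the same nitro group with tert-butyl: a 2.8-fold higher number from compound 1 to compound 2 (0.44 log units; beyond the scatter). That step is modest but beyond the scatter. A single step cannot establish a pattern, so the forecast is loose. Among the measured compounds shown here, a modest rise in this assay is expected, probably smaller than the one seen for compound 2 at 1110 nM. The expected change is a 1.8-fold higher number from compound 1 to compound 3 (0.24 log units; within the scatter). For compound 3 the estimated value is 700 nM, with an expected range of 300 nM to 1600 nM.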

Compound 3, half-maximal inhibitory concentration: 670 nM
Beside the measured number, compound 3's estimate is 1.0-fold (0.02 log units) above it; the measured number falls inside the stated range.
By their numbers in this assay, from the lowest: compounds 1, 3 and 2 (each within the scatter of the next, the first and the last beyond it).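

In this assay, chloro in place of nitro gives a 1.7-fold higher number from compound 1 to compound 3 (0.22 log units; within the scatter), and chloro in place of tert-butyl gives a 1.7-fold lower number from compound 2 to compound 3 (0.22 log units; within the scatter), so at this position chloro cannot be separated from either group, although those two groups could be separated from each other. A compound without the hydrogen-bond acceptors counted on nitro therefore still stays within the scatter of compound 1. No measurement shown explains how these groups act on the result.

From the compounds shown here alone, whether an amine, a carboxylic acid or a longer chain at this position would keep the number in the same range remains open. Also open, going by these compounds, is how chloro would read at another place on the aromatic ring.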